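Swapping the Amino Acid Side Chain on a Shared Core

The source may hold more compounds than are shown below. What is called first, only, known or untested is meant among the compounds shown, and "the series" means these compounds.

Of the compounds shown here, two have been measured in a functional assay on the whole organism (Tail, strain ICR) with Mus musculus as the target, in the tail flick test, with a stated time of 30 min, at a dose of 25 umol/kg by the oral route; on this read-out higher numbers stand for a stronger effect at the one dose given and lower numbers for a weaker effect. Compound 1, `NCCCC[C@H](NC(=O)CN(c1nc(Cl)nc2[nH]cnc12)C1CC1)C(=O)OCc1ccccc1`, gives 26.1%. Compound 2, `C[C@@H](O)[C@H](NC(=O)CN(c1ncnc2c1ncn2C1CCCCO1)C1CC1)C(=O)OCc1ccccc1`, gives 23.6%, and the two numbers lie within the usual scatter of each other, so neither can be set apart from the other. Compound 3, `CC(C)(C)OC(=O)NCCCC[C@H](NC(=O)CN(c1ncnc2c1ncn2C1CCCCO1)C1CC1)C(=O)OCc1ccccc1`, differs from compound 2 in one place: 4-((tert-butoxycarbonyl)amino)butyl in place of 1-hydroxyethyl on a saturated chain carbon bound to an amide-type nitrogen and a carbonyl carbon. Among the compounds with values here, no step between measured compounds gauges this change. The expected change, estimated as a number 1.4 percentage points higher from compound 2 to compound 3 (within the scatter), should stay within the scatter, in no firm direction. Compound 3 is therefore expected to give 25%, within a range of 10% to 40%.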

Compound 3, a percentage reported as activity, at one dose (the size of the read-out at that dose, not a potency): 18.3%
Compound 3: middle estimate off by 6.7 percentage points, on the high side, and the stated range covers the measured number.
By their numbers in this assay, from the lowest: compounds 3, 2 and 1 (each within the scatter of the next).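

In this assay, within the data shown here, this is the first step to gauge a change on the saturated chain carbon bound to an amide-type nitrogen and a carbonyl carbon. The step is a number 5.3 percentage points lower from compound 2 to compound 3 (within the scatter) and stays within the scatter, so the larger 4-((tert-butoxycarbonyl)amino)butyl group cannot be told apart from 1-hydroxyethyl here. Still open, from the compounds shown here alone, is how a free amine at the end of the butyl chain would read on this same core, as compound 1 differs in more than one place. No evidence given here explains this result.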